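A few compounds are considered here, and "the series" means these few. Any claim that something is new, unique, unknown or untested is made for them only; others in the source may bear on it.

In a physicochemical assay, read by spectrophotometry, with a stated time of 15 min (a lower number here means a stronger inhibitor, a higher number a weaker inhibitor), three compounds have been measured so far. Compound 3 (`O=C(CCCc1nc2ccccc2c(=O)[nH]1)N/N=C/c1cc(O)c(O)c(O)c1`) gives 45000000 nM and is the strongest inhibitor of the three. On the same scale, compound 1 (`O=C(CCc1nc2ccccc2c(=O)[nH]1)N/N=C/c1ccc(O)c(O)c1`) gives 105000000 nM and compound 2 (`O=C(CCc1nc2ccccc2c(=O)[nH]1)N/N=C/c1ccc(O)cc1`) gives 300000000 nM as the highest number.

Compound 4 (`COc1cc(/C=N/NC(=O)CCCc2nc3ccccc3c(=O)[nH]2)ccc1O`) has not yet been measured. It differs from compound 3 in one place (4-hydroxy-3-methoxyphenyl in place of 3,4,5-trihydroxyphenyl on a carbon with a double bond to nitrogen): 4-hydroxy-3-methoxyphenyl stands in place of 3,4,5-trihydroxyphenyl on a carbon with a double bond to nitrogen. Compared with compound 3, one hydroxy group gives way to hydrogen and another to methoxy.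

Among the measured compounds shown here, only one measured step bears on this. Hydrogen in place of hydroxy on an aromatic carbon gave a 2.9-fold higher number from compound 1 to compound 2 (0.46 log units; beyond the scatter) as a modest change. For the measured compounds named here, that step is only a guide, since compound 3 differs from compound 1 in more than the aromatic group, and no measured step covers a methoxy group. A step of similar size or somewhat larger is therefore expected in this assay, towards a higher number and a weaker inhibitor (a 3.1-fold higher number from compound 3 to compound 4 (0.49 log units; beyond the scatter)). The estimate for compound 4 is 140000000 nM (expected range 55000000 nM to 350000000 nM).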

Compound 4, half-maximal inhibitory concentration: 280000000 nM
Compound 4: the middle estimate sits 2.0-fold (0.30 log units) below what was measured, and the stated range covers the measured number.
By their numbers in this assay, from the lowest: compound 3; then compound 1; then compounds 4 and 2 (each within the scatter of the next).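

In this assay, among the compounds shown here, replacing 3,4,5-trihydroxyphenyl with 4-hydroxy-3-methoxyphenyl on the carbon with a double bond to nitrogen weakens inhibition, giving a 6.2-fold higher number from compound 3 to compound 4 (0.79 log units; beyond the scatter); this is the first measured step at this place that brings in a methoxy group, and the group entering has 1 hydrogen-bond donor where the group leaving has 3. The earlier step, a 2.9-fold higher number from compound 1 to compound 2 (0.46 log units; beyond the scatter), also went towards a higher number when hydroxy gave way to hydrogen, so in both single-place steps shown, the compound with fewer hydroxy groups on the aromatic ring is the weaker inhibitor, and neither step goes against this, although the new step is the larger of the two and involves a different change. Nothing measured here gives a reason for the rise in the number, whether for the hydroxy group lost or for the methoxy group gained.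

The new step carries both changes at once, so the compounds shown do not tell how much of it belongs to the lost hydroxy group and how much to the methoxy group. Also open, on these data alone, is how an amine or a carboxylic acid on the aromatic ring would fare in this assay, and whether a longer chain would alter these steps.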